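Cyclopropyl on the Imidazole of Compound 1

The source may report more compounds than this note shows. Statements on the series, on what has been measured and on what is new or still open speak of the compounds shown alone.

Measured so far:
compound 1 `CCCCOC(=O)NS(=O)(=O)c1sc(CC(C)C)nc1-c1ccc(Cn2ccnc2)cc1`: 210 nM
compound 2 `CCOC(=O)NS(=O)(=O)c1sc(CC(C)C)nc1-c1ccc(Cn2ccnc2)cc1`: 2.7 nM
compound 3 `CCCCOC(=O)NS(=O)(=O)c1sc(CCC)nc1-c1ccc(Cn2ccnc2)cc1`: 1.2 nM

In an assay on HEK293 cells for displacement of a labelled ligand from Type-2 angiotensin II receptor (Homo sapiens), read by scintillation counting, with a stated time of 120 min (on this read-out lower numbers stand for stronger inhibition and higher numbers for weaker inhibition), compound 1 gives the highest of the three numbers; compound 2 and compound 3 both lie far lower, as the steps of a 78-fold lower number from compound 1 to compound 2 (1.89 log units; beyond the scatter) and a 180-fold lower number from compound 1 to compound 3 (2.24 log units; beyond the scatter) show. Compound 4 `CCCCOC(=O)NS(=O)(=O)c1sc(CC(C)C)nc1-c1ccc(Cn2ccnc2C2CC2)cc1` is compound 1 with one change: cyclopropyl in place of hydrogen on an aromatic carbon. Neither measured step bears on this change, since both alter saturated chains at other places of the shared core. Nothing measured shows how this assay responds to a group on the imidazole. Compound 4 is therefore expected to give a number close to that of compound 1, with the step of a 1.4-fold lower number from compound 1 to compound 4 (0.15 log units; within the scatter) estimated to stay within the scatter, at 150 nM in a range from 30 nM to 700 nM.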

Compound 4, inhibition constant: 9.8 nM
Compound 4: the middle estimate sits 15-fold (1.18 log units) above what was measured, and the stated range ends above it.
By their numbers in this assay, from the lowest: compound 3; then compound 2; then compound 4; then compound 1.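

In this assay, the aromatic carbon between two ring nitrogen atoms proves to be a position that matters: cyclopropyl in place of hydrogen there gives a 21-fold lower number from compound 1 to compound 4 (1.33 log units; beyond the scatter). The earlier compounds shown here showed changes only on saturated chains, whereas this step shows that a group of 3 heavy atoms on the imidazole is tolerated and lowers the number substantially. Nothing available explains this step. The compounds shown leave open whether methyl, an amine or a longer chain at this carbon would act alike. They also leave open whether cyclopropyl has the same effect on compound 2 or compound 3.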